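The source may report more compounds than this note shows. Statements on the series, on what has been measured and on what is new or still open speak of the compounds shown alone.

Compound 1, with the structure `CC(Nc1ccccc1Oc1cccc(F)c1)=C1C(=O)CC(c2ccccc2)CC1=O`, was tested in a functional assay on CCRF-CEM cells (Homo sapiens) for antiproliferative activity, read by cell counting, with a stated time of 96 h (on this read-out lower numbers stand for stronger inhibition and higher numbers for weaker inhibition), where compound 1 gives 170 nM. A close relative, compound 2, with the structure `CC(=O)c1ccc(Oc2ccccc2NC(C)=C2C(=O)CC(c3ccccc3)CC2=O)cc1`, keeps the whole shared core and differs only in the group carried on the oxygen attached to the aromatic ring; in this assay compound 2 gives 220 nM. For the measured compounds named here, the one measured step, a 1.3-fold higher number from compound 1 to compound 2 (0.11 log units; within the scatter), shows that swapping the group at this position left the read-out essentially unchanged. On the two numbers available, compound 1 therefore stands alongside compound 2, with the gap between them inside the usual scatter.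

Compound 3, with the structure `COc1cc(Oc2ccccc2NC(C)=C2C(=O)CC(c3ccccc3)CC2=O)ccc1N`, changes compound 1 at the same position: 4-amino-3-methoxyphenyl in place of 3-fluorophenyl on an oxygen on an aromatic ring. Going by the values given here, the only step that bears on this change is the one from compound 1 to compound 2, and it was within the scatter, so no movement beyond the scatter is expected in this assay. The step from compound 1 to compound 3 is expected to be a 1.2-fold higher number from compound 1 to compound 3 (0.07 log units; within the scatter). Compound 3 is accordingly estimated at 200 nM, with a range from 80 nM to 500 nM.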

Compound 3, half-maximal inhibitory concentration: 12 nM
Compound 3: middle estimate off by 17-fold (1.22 log units), on the high side; measured number outside the range, below it.
By their numbers in this assay, from the lowest: compound 3; then compounds 1 and 2 (each within the scatter of the next).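

In this assay, this position proves far more sensitive than the earlier pair suggested: 4-amino-3-methoxyphenyl in place of 3-fluorophenyl gives a 14-fold lower number from compound 1 to compound 3 (1.15 log units; beyond the scatter), and 4-amino-3-methoxyphenyl in place of 4-acetylphenyl gives an 18-fold lower number from compound 2 to compound 3 (1.26 log units; beyond the scatter). The flat result seen earlier therefore holds only between the 3-fluorophenyl and 4-acetylphenyl groups, and the group on this oxygen can shift the read-out well beyond the scatter while the shared core stays the same. No measurement at hand explains why this change has so large an effect.

The amino and methoxy groups enter together, so the compounds shown cannot separate their contributions: it remains open whether 4-aminophenyl or 3-methoxyphenyl alone on this oxygen would keep the low number, or whether both groups are needed. As far as these compounds go, it is also open how far the result depends on the amine itself, for example whether a hydroxyl group or a methylamino group in its place would give a similar number.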